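The source may report more compounds than this note shows. Statements on the series, on what has been measured and on what is new or still open speak of the compounds shown alone.

Compound 1 `Cc1cc(NCc2ccccn2)n2ncc(Br)c2n1`: in a physicochemical assay for solubility, read by HPLC, using the shake flask method, measured as kinetic solubility, with a stated time of 2 h, at pH 7.4 (a lower number here means a less soluble compound, a higher number a more soluble compound), compound 1 gives 89300 nM.
Compound 2 `COc1ccc(-c2cnn3c(NCc4ccccn4)cc(C)nc23)cc1`: in this assay compound 2 gives < 5000 nM, a limit of the assay.
Compound 3 `Cc1cc(NCc2ccccn2)n2ncc(-c3ccccc3C)c2n1`: in this assay compound 3 gives < 5000 nM, also a limit of the assay.

Compound 3 thus stands at the limit of < 5000 nM in this assay, at which 2 of the 3 values shown sit, without a number of its own. Compound 4 `Cc1cc(NCc2ccccn2)n2ncc(-c3cc(F)c(F)c(F)c3)c2n1` differs from compound 3 by 3,4,5-trifluorophenyl in place of 2-methylphenyl on an aromatic carbon. Within the data shown here, no measured step covers this exchange of one substituted phenyl for another: the step that the two limits leave unreadable from compound 2 to compound 3 cannot be read between two limits, and the step of an at least 17-fold lower number from compound 1 to compound 3 (1.25 log units; beyond the scatter) shows only that a substituted phenyl in place of bromo brings the value down to the limit. The step from compound 3 to compound 4 in this assay is therefore expected to stay within the scatter, with the result most likely again reported as a limit. Compound 4 is estimated at 3000 nM, range 500 nM to 9000 nM. The expected step is a step that the limit leaves unreadable from compound 3 to compound 4.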

Compound 4, solubility: < 5000 nM
Compound 4: only a limit was reported; the forecaster's own chance of this, stated with the estimate: 80%; the middle value does not contradict the limit.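

A third substituted phenyl at this position gives the same outcome as the first two: 3,4,5-trifluorophenyl in place of bromo gives an at least 17-fold lower number from compound 1 to compound 4 (1.25 log units; beyond the scatter) in this assay. The steps among compound 2, compound 3 and compound 4 cannot be read, and no order of the three phenyl groups follows. The reported values now gather at one limit: the limit of < 5000 nM in this assay, at which 3 of the 4 values shown sit.

Open remains where each of these three compounds lies under that limit. Also open, as far as these compounds go, is whether an amine or a carboxylic acid on the phenyl ring, or in its place, gives a readable value.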